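The source may report more compounds than this note shows. Statements on the series, on what has been measured and on what is new or still open speak of the compounds shown alone.

In a functional assay on HCT-116 cells (Homo sapiens) for antiproliferative activity, read by radiometric assay, with a stated time of 72 h (on this read-out lower numbers stand for stronger inhibition and higher numbers for weaker inhibition), compound 1 `O=C(CCCCCCC(=O)Nc1cc2ncnc(Nc3ccc(Cl)cc3F)c2s1)NO` gives 1790 nM and compound 2 `CCc1ccc(Nc2ncnc3cc(NC(=O)CCCCCCC(=O)NO)sc23)cc1` gives 2360 nM, so these two values stand within the scatter of each other. Compound 3 `COc1ccc(Nc2ncnc3cc(NC(=O)CCCCCCC(=O)NO)sc23)cc1` differs from compound 2 in one place: methoxy in place of ethyl on an aromatic carbon, with methoxy in place of ethyl on an aromatic carbon. Within the data shown here, the one measured step, a 1.3-fold higher number from compound 1 to compound 2 (0.12 log units; within the scatter), put 4-ethylphenyl in place of 4-chloro-2-fluorophenyl and stayed within the scatter, so no step beyond the scatter is expected here. The expected step is a 1.2-fold lower number from compound 2 to compound 3 (0.07 log units; within the scatter). The estimated value for compound 3 is 2000 nM, with an expected range from 800 nM to 5000 nM.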

Compound 3, half-maximal inhibitory concentration: 2180 nM
Estimate against measurement, compound 3: 1.1-fold (0.04 log units) below; low and high end bracket the measured number.
By their numbers in this assay, from the lowest: compounds 1, 3 and 2 (each within the scatter of the next).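

Methoxy on this aromatic carbon, para to a large group, brings an oxygen and a hydrogen-bond acceptor that ethyl lacks, yet this assay shows a 1.1-fold lower number from compound 2 to compound 3 (0.03 log units; within the scatter). The other listed step, a 1.2-fold higher number from compound 1 to compound 3 (0.09 log units; within the scatter), also stays within the scatter, so all three aryl groups on this nitrogen give values within the scatter of each other. No measurement offered here accounts for this result. As far as these compounds go, it remains open whether an amine or a carboxylic acid at this carbon would give a step beyond the scatter.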